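Removing Fluorine From Urea Hydrazones Against Liver Cancer Cells

This account rests on a few compounds, and the source may have more. Where it says the series, first, only, none or still open, it means among the compounds named here.

Three compounds have been measured in a functional assay on HepG2 cells (Homo sapiens) for antiproliferative activity, read by MTT assay, with a stated time of 72 h; a lower number here means a stronger inhibitor, a higher number a weaker inhibitor:

Compound 1, `O=C(N/N=C/c1ccccc1)Nc1ccc(Oc2ccnc3[nH]ccc23)c(F)c1`, compound 1 gives 640 nM
Compound 2, `O=C(N/N=C/c1ccc(F)cc1)Nc1ccc(Oc2ccnc3[nH]ccc23)c(F)c1`, compound 2 gives 3880 nM
Compound 3, `COc1ccc(/C=N/NC(=O)Nc2ccc(Oc3ccnc4[nH]ccc34)c(F)c2)c(OC)c1OC`, compound 3 gives 2990 nM

Compound 2 and compound 1 differ in one place, (hydrogen in place of fluoro on an aromatic carbon), and that change produced a 6.1-fold lower number from compound 2 to compound 1 (0.78 log units; beyond the scatter). Compound 3 and compound 2 differ in more than one place, and the difference between their two cores is not broken down here; their two values lie within the usual scatter of each other, while compound 3 stands beyond the scatter from compound 1.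

Compound 4, `COc1ccc(/C=N/NC(=O)Nc2ccc(Oc3ccnc4[nH]ccc34)cc2)c(OC)c1OC`, has not yet been measured. It differs from compound 3 by hydrogen in place of fluoro on an aromatic carbon. Within the data shown here, this is the same kind of change as the one from compound 2 to compound 1, but not the same: there the fluoro sat para to a large group, whereas here it sits ortho to a large group and meta to a large group. Among the measured compounds shown here, the single precedent, a 6.1-fold lower number from compound 2 to compound 1 (0.78 log units; beyond the scatter), thus concerns a fluoro at a different place, and no step at this place has been measured. The expected step from compound 3 to compound 4 in this assay is a 1.7-fold lower number from compound 3 to compound 4 (0.22 log units; within the scatter), a more cautious expectation than the earlier step, resting only on that precedent and on the mismatch in place. Compound 4 is therefore estimated at 1800 nM, between 600 nM and 5500 nM.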

Compound 4, half-maximal inhibitory concentration: 2960 nM
Estimate against measurement, compound 4: 1.6-fold (0.22 log units) below, and the stated range covers the measured number.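

In this assay, putting hydrogen in place of fluoro on the ring of compound 3 gave a 1.0-fold lower number from compound 3 to compound 4 (0.00 log units; within the scatter), so the clear step seen earlier did not reappear on this core. The change therefore did not carry over in size from one core to the other, and the two steps stand apart: the same change on two cores in this assay, a 6.1-fold lower number (0.78 log units; beyond the scatter) from compound 2 to compound 1 and a 1.0-fold lower number (0.00 log units; within the scatter) from compound 3 to compound 4, 6.0-fold (0.78 log units) apart, beyond the scatter of two such steps This does not show what sets the two steps apart, since the fluoro leaves a different place in each, the cores also differ in their methoxy groups, and one step on each side cannot separate these factors or support a rule for the series.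

The compounds shown leave open whether a chloro or a methyl group at the place ortho to a large group and meta to a large group would give a value closer to that of the fluoro compound 3 or the hydrogen compound 4. They also leave open whether removing fluoro would matter on a core bearing an amine or a carboxylic acid in place of the methoxy groups, and whether a single methoxy group would behave like the set carried by compound 3.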